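Swapping the aryl cap on a nitroimidazole-oxadiazole series

The source may hold more compounds than are shown below. What is called first, only, known or untested is meant among the compounds shown, and "the series" means these compounds.

Within the data shown here, the three compounds measured so far share one core and differ only in the aromatic group attached to it. Compound 1 `Cc1ccc(-c2nnc(SCCn3c([N+](=O)[O-])cnc3C)o2)cc1` gives the lowest number of the three in a functional assay on SGC-7901 cells (Homo sapiens) for cytotoxicity, read by MTT assay, with a stated time of 48 h (a lower number here means a stronger inhibitor, a higher number a weaker inhibitor), with 12500 nM. Compound 2 `Cc1ncc([N+](=O)[O-])n1CCSc1nnc(-c2ccccc2N)o1` gives 35100 nM, and compound 3 `Cc1ncc([N+](=O)[O-])n1CCSc1nnc(-c2ccccc2Cl)o1` gives 32600 nM. Both replacements of the 4-methylphenyl group weakened the effect by a modest amount: a 2.8-fold higher number from compound 1 to compound 2 (0.45 log units; beyond the scatter) and a 2.6-fold higher number from compound 1 to compound 3 (0.42 log units; beyond the scatter). Between the two replacements themselves the difference is small, a 1.1-fold lower number from compound 2 to compound 3 (0.03 log units; within the scatter).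

Compound 4 `Cc1ncc([N+](=O)[O-])n1CCSc1nnc(-c2cnccc2N)o1` has not yet been measured. It differs from compound 1 in one place: 4-aminopyridin-3-yl in place of 4-methylphenyl on an aromatic carbon. The change resembles the two measured swaps in that the 4-methylphenyl group is again replaced, and the entering group carries an amino group as in compound 2. On that basis a modest rise in the number is expected in this assay, in the direction seen for compound 2 and compound 3, rather than no change or a fall.

The expected step is a 2.8-fold higher number from compound 1 to compound 4 (0.45 log units; beyond the scatter). For compound 4 the estimated value in this assay is 35000 nM, with a plausible range from 15000 nM to 85000 nM.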

Compound 4, half-maximal inhibitory concentration: 34500 nM
For compound 4 the middle estimate is 1.0-fold (0.01 log units) above the measured one; the range from low to high includes it.
By their numbers in this assay, from the lowest: compound 1; then compounds 3, 4 and 2 (each within the scatter of the next).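

In this assay, a third replacement of the 4-methylphenyl group, this time by a six-membered aromatic ring with a hetero atom, again costs a modest amount: a 2.8-fold higher number from compound 1 to compound 4 (0.44 log units; beyond the scatter). The new compound also cannot be told apart from the two earlier replacements, with a 1.1-fold higher number from compound 3 to compound 4 (0.02 log units; within the scatter) and a 1.0-fold lower number from compound 2 to compound 4 (0.01 log units; within the scatter), so a chloro group, an amino group and a ring nitrogen all end up at the same level, and among these four compounds only compound 1 stands apart. No evidence is available on what lies behind this shared level.

Each replacement swaps the 4-methylphenyl group for a ring that differs from it in more than one way, so these compounds cannot show whether the rise comes from losing the methyl group or from what enters in its place, and plain phenyl, 4-chlorophenyl or 4-aminophenyl would help to separate the two. Also open, as far as these compounds go, is whether this position needs an aromatic ring at all, which a cyclohexyl group or a short alkyl chain would test.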